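The source may hold more compounds than are shown below. What is called first, only, known or untested is meant among the compounds shown, and "the series" means these compounds.

The series shares one core bearing an ethoxycarbonyl group, a phenyl group and a chlorinated aryl group. Compound 1 `CCOC(=O)c1c(-c2ccc(Cl)cc2)cc(-c2ccccc2)nc1N1CCCCC1` gives 36.4% in a functional assay on the whole organism (strain Wister albino) for inhibition, with Rattus norvegicus as the target, read by paw edema, with stated times of 1 h and 24 h, at a dose of 50 mg/kg by the intraperitoneal route; a higher number here means more inhibition at the dose given (going by the name of the read-out), a lower number less inhibition. Compound 2 `CCOC(=O)c1c(-c2ccc(Cl)c(Cl)c2)cc(-c2ccccc2)nc1N1CCCCC1` gives 48.9%, and compound 3 `CCOC(=O)c1c(-c2ccc(Cl)cc2)cc(-c2ccccc2)nc1N1CCN(C)CC1` gives 53.2%. Two single-point steps are known: a number 12.5 percentage points higher from compound 1 to compound 2 (beyond the scatter), and a number 16.8 percentage points higher from compound 1 to compound 3 (beyond the scatter). Compound 2 thus stands second of the three numbers: its gap to compound 3 is within the scatter, so no order between those two can be read, while compound 1 lies beyond the scatter below it.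

Compound 4 `CCOC(=O)c1c(-c2ccc(Cl)c(Cl)c2)cc(-c2ccccc2)nc1Nc1ccc(Cl)cc1` is not yet measured. It differs from compound 2 by (4-chlorophenyl)amino in place of piperidin-1-yl on an aromatic carbon. Neither measured step covers this change directly; the nearest guide is a number 16.8 percentage points higher from compound 1 to compound 3 (beyond the scatter), which shows that exchanging the piperidin-1-yl group can move the read-out modestly. With one such example, no direction can be fixed. The expectation for compound 4 is therefore a step near zero, a number 1.1 percentage points higher from compound 2 to compound 4 (within the scatter), with room for a modest move either way. Compound 4 is estimated at 50%, in the range 35% to 65%.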

Compound 4, a percentage reported as inhibition, in the whole organism at one dose (the size of the read-out at that dose, not a potency): 52.7%
Compound 4: the middle estimate sits 2.7 percentage points below what was measured, and the stated range covers the measured number.
By their numbers in this assay, from the lowest: compound 1; then compounds 2, 4 and 3 (each within the scatter of the next).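

In this assay, at the aromatic carbon next to the ring nitrogen and ortho to an ethoxycarbonyl group, the exchange gives a number 3.8 percentage points higher from compound 2 to compound 4 (within the scatter), so on the 3,4-dichlorophenyl-bearing core no difference can be read between (4-chlorophenyl)amino and piperidin-1-yl. This position therefore accepts a six-membered aromatic ring of carbon only, carried on an amino nitrogen with 1 hydrogen-bond donor, in place of a six-membered non-aromatic ring, without a step beyond the scatter. No measurement on hand accounts for the size of this step.

As far as these compounds go, what the chlorine of the (4-chlorophenyl)amino group contributes remains open, as does how a plain phenylamino or a morpholin-4-yl group would read at this position. Also open, from the compounds shown here alone, is whether a carboxylic acid in place of the ethoxycarbonyl group would shift the read-out.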